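Pyrazole-bearing core series: oral exposure notes

The compounds below may be only part of what the source reports. "The series", "measured", "known", "first", "only" and "open" are said of these compounds alone.

Measured compounds:
- compound 1 `Cc1cn2c(-c3cn[nH]c3)cnc2c(Nc2cc(Cc3cnccn3)ns2)n1`: 58.4 ng.h/mL
- compound 2 `Cc1cn2c(-c3cn[nH]c3)cnc2c(Nc2cc(Cc3cccnc3)ns2)n1`: "not determined" (no result reported)
- compound 3 `Cc1cn2c(-c3cn[nH]c3)cnc2c(Nc2cc(Cc3ccncc3)ns2)n1`: "not determined" (no result reported)

In an ADME assay on the whole organism for pharmacokinetics, with Rattus norvegicus as the target, with a stated time of 6 h, at a dose of 10 mg/kg by the oral route (on this read-out higher numbers stand for higher exposure at the dose given and lower numbers for lower exposure), compound 1 gives 58.4 ng.h/mL. For compound 2 this assay records "not determined" (no result reported). Compound 3 likewise stands without a number, this assay recording "not determined" (no result reported); so compound 3 has no position of its own on the read-out, and one further compound of the series shares that gap. For the measured compounds named here, no step between two measured compounds exists in this assay.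

Compound 4 `Cc1cn2c(-c3cn[nH]c3)cnc2c(Nc2cc(Cc3cccc(F)n3)ns2)n1` differs from compound 3 in one place: 6-fluoropyridin-2-yl in place of pyridin-4-yl on a saturated chain carbon bound to an aromatic carbon. With compound 3 unmeasured, the size and direction of this step in this assay cannot be anchored; no expectation beyond the scatter is held in either direction. Going by the values given here, the only footing is compound 1 with 58.4 ng.h/mL, and the estimate for compound 4 is placed near it with a wide range. Compound 4 is expected to give about 60 ng.h/mL, from 10 ng.h/mL to 400 ng.h/mL.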

Compound 4, area under the concentration-time curve: 2970 ng.h/mL
Beside the measured number, compound 4's estimate is 50-fold (1.69 log units) below it; measured number above the stated range.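

In this assay, the group on the saturated chain carbon bound to an aromatic carbon proves a strong lever: with the rest of the structure unchanged, 6-fluoropyridin-2-yl in place of pyrazin-2-yl goes with a 51-fold higher number from compound 1 to compound 4 (1.71 log units; beyond the scatter). For the compounds shown here, this is the first readable step, and it shows that oral exposure can shift well beyond the scatter through this one group alone. No measurement at hand bears on the origin of this step.

From the compounds shown here alone, the steps from compound 2 and from compound 3 to compound 4 cannot be read, as neither compound has a number, so the share of the fluorine alone remains unknown. Also open, going by these compounds, is whether a methyl group or a chlorine in place of that fluorine would keep the exposure of compound 4.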